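Growth Inhibition Unmoved as the Side Chain Lengthens

The source may hold more compounds than are shown below. What is called first, only, known or untested is meant among the compounds shown, and "the series" means these compounds.

Of the compounds shown here, three sharing one core have been measured in a functional assay on HOS cells (Homo sapiens) for antiproliferative activity, read by sulforhodamine B assay; on this read-out lower numbers stand for stronger inhibition of growth and higher numbers for weaker inhibition of growth. Compound 1 `O[C@H]1CO[C@H](COCc2ccccc2)[C@@H](OCc2ccccc2)[C@@H]1OCc1ccccc1`, which carries hydrogen on the ring carbon where the others carry a chain, gives 37900 nM. Compound 2 `CC[C@@H]1O[C@H](COCc2ccccc2)[C@@H](OCc2ccccc2)[C@H](OCc2ccccc2)[C@H]1O`, the ethyl member, gives 34200 nM. Compound 3 `CCC[C@@H]1O[C@H](COCc2ccccc2)[C@@H](OCc2ccccc2)[C@H](OCc2ccccc2)[C@H]1O`, the propyl member, gives 38600 nM, which lies within the scatter of both other numbers.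

Compound 4 `CCCC[C@@H]1O[C@H](COCc2ccccc2)[C@@H](OCc2ccccc2)[C@H](OCc2ccccc2)[C@H]1O` is the next member of the series, and its difference from compound 3 is methyl in place of hydrogen on a saturated chain carbon, three bonds along the chain from a saturated ring carbon. This is methyl in place of hydrogen on a saturated chain carbon, three bonds along the chain from a saturated ring carbon, so propyl becomes butyl.

Among the compounds with values here, the closest precedent is the change from ethyl to propyl, a 1.1-fold higher number from compound 2 to compound 3 (0.05 log units; within the scatter). The two larger changes from hydrogen are also small, at a 1.1-fold lower number from compound 1 to compound 2 (0.04 log units; within the scatter) and a 1.0-fold higher number from compound 1 to compound 3 (0.01 log units; within the scatter). None of these three steps leaves the scatter, although no chain as long as butyl has yet been measured. The step expected in this assay is therefore none beyond the scatter, an estimated 1.1-fold lower number from compound 3 to compound 4 (0.04 log units; within the scatter). For compound 4 the expected value is 35000 nM, with an estimated range from 18000 nM to 60000 nM.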

Compound 4, concentration for 50% growth inhibition: 40100 nM
For compound 4 the middle estimate is 1.1-fold (0.06 log units) below the measured one, within the range that was stated.
By their numbers in this assay, from the lowest: compounds 2, 1, 3 and 4 (each within the scatter of the next).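

The series now reaches butyl, and in this assay the added methyl, three bonds along the chain from a saturated ring carbon, gives a 1.0-fold higher number from compound 3 to compound 4 (0.02 log units; within the scatter), so a chain of this length also stays within the scatter. Within the data shown here, the wider comparisons agree: going from ethyl to butyl gives a 1.2-fold higher number from compound 2 to compound 4 (0.07 log units; within the scatter), and the whole change from hydrogen to butyl on the saturated ring carbon gives a 1.1-fold higher number from compound 1 to compound 4 (0.02 log units; within the scatter), which means that no pair among the four compounds separates at this position. Nothing available here accounts for this flat response.

From the compounds shown here alone, whether any group at this position can move the number beyond the scatter stays open, since a longer chain such as octyl, or an amine or a carboxylic acid on the chain, might not behave like the plain chains from ethyl to butyl. All four compounds also keep the benzyl ethers on the shared core, so what those groups contribute to growth inhibition, and whether the flat response would persist with hydroxyl in their place, cannot be told from these numbers.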